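A few compounds are considered here, and "the series" means these few. Any claim that something is new, unique, unknown or untested is made for them only; others in the source may bear on it.

Compound 1 `CCN(CC)c1cc2[nH]c(C3CCCCC3)nc2cc1NC(=O)c1ccc(OC(F)(F)F)cc1` was tested in an ADME assay on Vero cells (Chlorocebus sabaeus) for cytotoxicity, read by resazurin assay, with a stated time of 3 days (on this read-out higher numbers stand for weaker inhibition and lower numbers for stronger inhibition), where compound 1 gives > 100 ug/mL, a limit of the assay rather than a number. Compound 2 `CCCOCC(=O)Nc1cc2nc(C3CCCCC3)[nH]c2cc1N(C)C` also sits at a limit, giving < 50 ug/mL in this assay. Compound 3 `CCCCOC(=O)Nc1cc2nc(C3CCCCC3)[nH]c2cc1N(C)C` likewise reaches a limit, with > 100 ug/mL in this assay. Going by the values given here, the only step between measured compounds is an at least 2.0-fold higher number from compound 2 to compound 3 (0.30 log units; that floor lies within the scatter), resting on the limit of < 50 ug/mL in this assay, at which 1 of the 3 values shown sits, and (the limit of > 100 ug/mL in this assay, at which 2 of the 3 values shown sit). Compound 4 `CCCC(C)OC(=O)Nc1cc2nc(C3CCCCC3)[nH]c2cc1N(CC)CC` differs from compound 1 by 1-methylbutoxy in place of 4-(trifluoromethoxy)phenyl on a carbonyl carbon. Among the compounds with values here, no measured step bears directly on this change, though compound 3 carries a related carbamate and stands at the same limit as compound 1. Compound 4 is therefore expected to show a step that the limit leaves unreadable from compound 1 to compound 4. The estimate for compound 4 is 130 ug/mL, within 60 ug/mL to 300 ug/mL.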

Compound 4, half-maximal inhibitory concentration: > 100 ug/mL
Compound 4: a limit, no number; the forecaster's own chance of this, stated with the estimate: 75%; the middle value lies beyond the limit too.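

Compound 1 and compound 4 both stand at the same limit in this assay, and no step between them can be read: the limit of > 100 ug/mL in this assay, at which 3 of the 4 values shown sit.

The compounds shown leave open whether 1-methylbutoxy in place of 4-(trifluoromethoxy)phenyl on a carbonyl carbon changes this read-out at all.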